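This account rests on a few compounds, and the source may have more. Where it says the series, first, only, none or still open, it means among the compounds named here.

Measured in an ADME assay for permeability, using PAMPA, at pH 7.4; a lower number here means that the compound crosses the layer more slowly, a higher number that the compound crosses the layer faster:
- Compound 1 `O=C(O)c1cccc2cc(Cn3ccc4ccncc4c3=O)oc12`: 9 nm/s
- Compound 2 `O=C(O)c1cc(Cl)cc2cc(CNC(=O)c3cnn4cccnc34)oc12`: 7 nm/s
- Compound 3 `C[C@@H](OC(=O)c1cc(Cl)cc2cc(CNC(=O)c3cnn4cccnc34)oc12)C(F)(F)F`: "not determined" (no result reported)

Compound 1 and compound 2 lie within the usual scatter of each other, so the two measured compounds give one level and no trend. Compound 3 stands outside that comparison: in this assay its entry for compound 3 reads "not determined" (no result reported), and it therefore offers no number to start from.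

The next compound is compound 4 `O=C(NCc1cc2cc(Cl)cc(-c3nn[nH]n3)c2o1)c1cnn2cccnc12`, which has not yet been measured. The change is 2H-tetrazol-5-yl in place of (1-(trifluoromethyl)ethoxy)carbonyl on an aromatic carbon. Compound 4 keeps the chloro group and the amide side chain of compound 2, and differs from it in carrying the 2H-tetrazol-5-yl group where compound 2 has a free carboxyl group.

Among the compounds with values here, with no measured step to draw on, the nearest reference is compound 2 at 7 nm/s. In this assay, the expectation is therefore for no change beyond the scatter from that level, with any drift more likely downward than upward. For compound 4 the expected value is 5 nm/s, within an estimated range of 1.5 nm/s to 15 nm/s.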

Compound 4, apparent permeability: 2 nm/s
For compound 4 the middle estimate is 2.5-fold (0.40 log units) above the measured one; the range from low to high includes it.
By their numbers in this assay, from the lowest: compound 4; then compounds 2 and 1 (each within the scatter of the next).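

In this assay, the change of carboxy to 2H-tetrazol-5-yl, on the aromatic carbon meta to the chloro group, gives a 3.5-fold lower number from compound 2 to compound 4 (0.54 log units; beyond the scatter). Within the data shown here, this is the first step between measured compounds that differ in one place, and it shows that the number responds to what is carried at this position, even though both groups here are small and neither carries a net charge as drawn. The measured compounds offer nothing that bears on why the number moved in this direction.

The step from the ester of compound 3 cannot be read, as that compound has no result, so the shared amide series still rests on a single comparison and says nothing about how an uncharged group at this position would compare. On these data alone, it also remains open whether a primary amide, a nitrile or a methyl sulfonamide on the same aromatic carbon would stay with the carboxy compound or fall with the tetrazole, and whether the same change would give a similar step with the chloro group replaced by hydrogen.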